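Dimethylamino to methylsulfanyl on the shared purine-like core

The source may hold more compounds than are shown below. What is called first, only, known or untested is meant among the compounds shown, and "the series" means these compounds.

Compound 1 `CN(C)c1nc(N)c2ncn([C@@H]3C[C@@H](O)[C@H](CO)O3)c2n1` is the reference of this pair. In a functional assay on MOLT-4 cells (Homo sapiens) (a higher number here means a weaker inhibitor, a lower number a stronger inhibitor), compound 1 gives only a limit, > 300 uM, not a measured number. Compound 2 `CN(C)c1nc(Br)nc2c1ncn2[C@@H]1C[C@@H](O)[C@H](CO)O1` carries a different group on the shared core. In this assay compound 2 likewise gives only a limit, > 300 uM. Compound 1 therefore stands at the limit of > 300 uM in this assay, at which 2 of the 2 values shown sit, and no ordering among the shown compounds is possible.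

Compound 3 `CSc1nc(N)c2ncn([C@@H]3C[C@@H](O)[C@H](CO)O3)c2n1` is the compound still to be tested. It differs from compound 1 by a single change (methylsulfanyl in place of dimethylamino on an aromatic carbon), on an aromatic carbon of a six-membered aromatic ring with 2 nitrogen, part of a fused or bridged system of two rings.

Among the compounds with values here, no step between measured compounds is available to guide the size. With both shown values at the limit, nothing points to a gain, and the expected step from compound 1 to compound 3 is a number no higher from compound 1 to compound 3 (the limit leaves the size open), none beyond the scatter. For compound 3 the expected value in this assay is 300 uM, in the range 100 uM to 1000 uM, most likely again reported only as a limit.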

Compound 3, concentration for 50% inhibition: > 300 uM
Compound 3: only a limit was reported; the forecaster's own chance of this, stated with the estimate: 75%; the middle value lies on the limit itself.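

In this assay compound 3 gives > 300 uM, which is a limit. Compound 1 also gives only a limit, so no step from compound 1 to compound 3 can be read: the limit of > 300 uM in this assay, at which 3 of the 3 values shown sit.

The compounds shown leave open what change on the shared core would give a readable value in this assay.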